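This account rests on a few compounds, and the source may have more. Where it says the series, first, only, none or still open, it means among the compounds named here.

In an in vitro ADME assay on microsomes from liver (Homo sapiens) for metabolic stability (on this read-out higher numbers stand for fast clearance and lower numbers for slow clearance), three compounds that differ in one group on a shared core have been measured. Compound 1 (`Fc1ccccc1Cc1nc(-c2nc(C(F)F)n[nH]2)n2ccccc12`) with difluoromethyl gives 62 mL.min-1.g-1 as its number. Compound 2 (`Cc1n[nH]c(-c2nc(Cc3ccccc3F)c3ccccn23)n1`) with methyl gives 124 mL.min-1.g-1 on the same scale. Compound 3 (`CS(=O)(=O)c1n[nH]c(-c2nc(Cc3ccccc3F)c3ccccn23)n1`) with methylsulfonyl gives 11 mL.min-1.g-1 and so holds the lowest of the three numbers. Compound 4 (`Fc1ccccc1Cc1nc(-c2ncn[nH]2)n2ccccc12`) has hydrogen in place of methylsulfonyl on an aromatic carbon and is still unmeasured.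

Within the data shown here, no measured compound carries hydrogen at that spot, so the closest guide is what happened when methylsulfonyl came in. That change gave a 5.6-fold lower number from compound 1 to compound 3 (0.75 log units; beyond the scatter) and an 11-fold lower number from compound 2 to compound 3 (1.05 log units; beyond the scatter) in the two measured cases. Putting methyl in place of difluoromethyl gave only a 2.0-fold higher number from compound 1 to compound 2 (0.30 log units; within the scatter) as its step. If hydrogen tracks those two groups rather than methylsulfonyl, a modest to large rise is expected in this assay on removing methylsulfonyl. That rise is estimated as a 5.5-fold higher number from compound 3 to compound 4 (0.74 log units; beyond the scatter) in the expected direction. Compound 4 is expected at about 60 mL.min-1.g-1 with a likely range of 25 mL.min-1.g-1 to 130 mL.min-1.g-1 around it.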

Compound 4, intrinsic clearance in microsomes: 175 mL.min-1.g-1
The estimate for compound 4 lay 2.9-fold (0.46 log units) below the measured number; measured number above the stated range.
By their numbers in this assay, from the lowest: compound 3; then compounds 1, 2 and 4 (each within the scatter of the next, the first and the last beyond it).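

Taking methylsulfonyl off the ring in this assay gives a 16-fold higher number from compound 3 to compound 4 (1.20 log units; beyond the scatter) and so shows that the low number of compound 3 is not shared by the unsubstituted position, where hydrogen sits. Hydrogen and methyl cannot be told apart, with a 1.4-fold higher number from compound 2 to compound 4 (0.15 log units; within the scatter) staying within the scatter, whereas hydrogen and difluoromethyl do separate, with a 2.8-fold higher number from compound 1 to compound 4 (0.45 log units; beyond the scatter) lying beyond it, so among these four groups methylsulfonyl alone gives a low number. Nothing measured here explains why these groups differ.

Still open, from the compounds shown here alone, is whether a low number needs methylsulfonyl itself or would also appear with a related group at this position, such as a sulfonamide or an ethylsulfonyl group. A nitrile, an amine or a carboxylic acid there could show how far the effect extends beyond sulfur-containing groups.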